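From 1H-pyrrol-2-yl to isobutyl on a carbonyl carbon

A few compounds are considered here, and "the series" means these few. Any claim that something is new, unique, unknown or untested is made for them only; others in the source may bear on it.

In a functional assay on HepG2 cells (Homo sapiens) for inhibition, read by sulforhodamine B assay, with a stated time of 3 days (on this read-out higher numbers stand for weaker inhibition and lower numbers for stronger inhibition), compound 1 (`COc1ccc(C(=O)Nc2ccc3c(c2)/C(=C/Nc2cccc(N4CCN(C)CC4)c2)C(=O)N3)cc1`) gives 1780 nM, compound 2 (`CN1CCN(c2cccc(N/C=C3\C(=O)Nc4ccc(NC(=O)c5c(F)cccc5F)cc43)c2)CC1`) gives 3030 nM and compound 3 (`CN1CCN(c2cccc(N/C=C3\C(=O)Nc4ccc(NC(=O)c5ccc[nH]5)cc43)c2)CC1`) gives 5370 nM. Two steps show where the pyrrolyl compound stands: a 1.8-fold higher number from compound 2 to compound 3 (0.25 log units; within the scatter), and a 3.0-fold higher number from compound 1 to compound 3 (0.48 log units; beyond the scatter). Compound 4 (`CC(C)CC(=O)Nc1ccc2c(c1)/C(=C/Nc1cccc(N3CCN(C)CC3)c1)C(=O)N2`) carries isobutyl in place of 1H-pyrrol-2-yl on a carbonyl carbon. The measured swaps at this same place are modest at most, the remaining one being a 1.7-fold higher number from compound 1 to compound 2 (0.23 log units; within the scatter). None of them tests a group without a ring, so the size of this step is uncertain, and no change beyond the scatter is expected. The expected change is a 1.5-fold lower number from compound 3 to compound 4 (0.19 log units; within the scatter). Compound 4 is estimated at 3500 nM, with an expected range from 1300 nM to 9500 nM.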

Compound 4, half-maximal inhibitory concentration: 5070 nM
Beside the measured number, compound 4's estimate is 1.4-fold (0.16 log units) below it; the measured number falls inside the stated range.
By their numbers in this assay, from the lowest: compounds 1, 2, 4 and 3 (each within the scatter of the next, the first and the last beyond it).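

In this assay, the first group without a ring on this carbonyl carbon stays within the scatter of two ring-bearing groups, a 1.1-fold lower number from compound 3 to compound 4 (0.02 log units; within the scatter) and a 1.7-fold higher number from compound 2 to compound 4 (0.22 log units; within the scatter), so among these compounds neither a ring nor the hydrogen-bond donor of 1H-pyrrol-2-yl is needed to stay in this range. Only the 4-methoxyphenyl group stands apart from isobutyl, a 2.8-fold higher number from compound 1 to compound 4 (0.45 log units; beyond the scatter). No measurement shown here accounts for these numbers. From the compounds shown here alone, whether an amine, a carboxylic acid or a longer chain on this carbonyl carbon would leave this range remains open.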